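A Methyl Gives Way to Fluoro at the Assay Limit

This account rests on a few compounds, and the source may have more. Where it says the series, first, only, none or still open, it means among the compounds named here.

Compound 1 `Fc1cccc(F)c1Cn1c(-c2c(F)cccc2F)nc2cnccc21`: > 100000 nM
Compound 2 `Cc1ccc(Cn2ccc3nc(-c4ccccc4)nc-3c2)cc1`: > 100000 nM

Both entries come from an ADME assay on MDBK cells (Bos taurus) for cytotoxicity; a higher number here means that more compound is tolerated, a lower number that less compound is tolerated. Compound 1 gives > 100000 nM, which is a limit of the assay and not a number. Compound 2 gives > 100000 nM, which is likewise a limit and not a number. Compound 2 therefore stands with no exact value, and the evidence so far is the limit of > 100000 nM in this assay, at which 2 of the 2 values shown sit.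

Compound 3 `Fc1ccc(Cn2ccc3nc(-c4ccccc4)nc-3c2)cc1` is still to be measured in this assay. It differs from compound 2 in one place, with fluoro in place of methyl on an aromatic carbon, para to a large group, so that 4-methylphenyl becomes 4-fluorophenyl (fluoro in place of methyl on an aromatic carbon). Within the data shown here, no measured pair shows the size of a single change here, so the expectation leans on compound 2 alone, with its limit of > 100000 nM. No shift beyond the scatter is expected in either direction. The expected change a number no higher from compound 2 to compound 3 (the limit leaves the size open) is accordingly small, and the assay will probably report only a limit again. For compound 3 the estimated value is 100000 nM, with an expected range of 50000 nM to 200000 nM.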

Compound 3, half-maximal cytotoxic concentration: > 100000 nM
Compound 3 ended at the assay's limit (the forecaster's own chance of this, stated with the estimate: 85%); the middle value lies on the limit itself.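

In this assay, compound 2 and compound 3 both report only a limit and not a number, so no step can be read for the change from 4-methylphenyl to 4-fluorophenyl. The compounds shown leave open how much of any of them is actually tolerated, and whether any structural change would produce a measurable value: the limit of > 100000 nM in this assay, at which 3 of the 3 values shown sit.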